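This account rests on a few compounds, and the source may have more. Where it says the series, first, only, none or still open, it means among the compounds named here.

Measured compounds:
compound 1, `CC#CCNC(=O)c1cccc2c1cc(C)n2-c1nc2c(c(NCc3ccccc3)n1)CCCC2`: 723 nM
compound 2, `CC#CCNC(=O)c1cccc2c1cc(C)n2-c1nc2c(c(NCc3ccccc3)n1)COCC2`: 524 nM
compound 3, `C#CC(=O)Nc1cccc2c1cc(C)n2-c1nc2c(c(NCc3ccccc3)n1)CCCC2`: 131 nM

In a functional assay on MIA PaCa-2 cells (Homo sapiens) for antiproliferative activity (on this read-out lower numbers stand for an effect already at smaller amounts and higher numbers for an effect only at larger amounts of compound), compound 1 gives 723 nM and compound 2 gives 524 nM; these two values lie within the scatter of each other. The two compounds differ in their cores, and the difference between the two cores is not broken down here. Compound 3, which gives 131 nM in this assay, is made from compound 1 by the change (a group of 5 heavy atoms (3 carbon, 1 nitrogen, 1 oxygen; no ring) in place of a group of 7 heavy atoms (5 carbon, 1 nitrogen, 1 oxygen; no ring), on an aromatic carbon), and this step gave a 5.5-fold lower number from compound 1 to compound 3 (0.74 log units; beyond the scatter).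

Compound 4, `C#CC(=O)Nc1cccc2c1cc(C)n2-c1nc2c(c(NCc3ccccc3)n1)COCC2`, has not yet been measured. It stands to compound 2 as compound 3 stands to compound 1: the change is a group of 5 heavy atoms (3 carbon, 1 nitrogen, 1 oxygen; no ring) in place of a group of 7 heavy atoms (5 carbon, 1 nitrogen, 1 oxygen; no ring), on an aromatic carbon, at a place described in the same words as for compound 3, so it is the same change on the other core.

Since compound 1 and compound 2 are within scatter of each other, compound 4 is expected to follow the step seen from compound 1 to compound 3, giving an estimated 5.5-fold lower number from compound 2 to compound 4 (0.74 log units; beyond the scatter). For compound 4 the estimate in this assay is 95 nM, expected to fall between 40 nM and 250 nM.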

Compound 4, half-maximal effective concentration: 78.7 nM
Estimate against measurement, compound 4: 1.2-fold (0.08 log units) above; measured number inside the range.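

In this assay, putting the (ethynylcarbonyl)amino group in place of the larger chain on the aromatic carbon gave a 6.7-fold lower number from compound 2 to compound 4 (0.82 log units; beyond the scatter). On the two cores shown, the change therefore carries over, and the size of its effect on the core of compound 2 matches that on the core of compound 1: the same change on two cores in this assay, a 5.5-fold lower number (0.74 log units; beyond the scatter) from compound 1 to compound 3 and a 6.7-fold lower number (0.82 log units; beyond the scatter) from compound 2 to compound 4, 1.2-fold (0.08 log units) apart, within the scatter of two such steps. This is one matched pair on each of two closely related cores in a single cell assay, so it shows that the step transfers between these two cores but not that it would hold on a third core, and it gives no reason for the size of the step.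

The compounds shown leave open whether the same step would appear with an acryloyl amide or a longer alkynyl chain in place of the (ethynylcarbonyl)amino group. They also leave open whether it would survive if the benzylamino group were exchanged for another amine, such as a morpholine or a cyclohexylamine.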